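The source may report more compounds than this note shows. Statements on the series, on what has been measured and on what is new or still open speak of the compounds shown alone.

Compound 1 `Oc1ccccc1/C=N/c1nnc(SCc2nnc(-c3ccccc3Cl)o2)s1` gives 18100 nM in a functional assay on MCF7 cells (Homo sapiens) for inhibition, read by CCK-8 assay (on this read-out higher numbers stand for weaker inhibition and lower numbers for stronger inhibition), the highest of the two numbers measured. Compound 2 `Cc1ccccc1-c1nnc(CSc2nnc(/N=C/c3ccccc3O)s2)o1` gives 9360 nM in this assay, and a 1.9-fold lower number from compound 1 to compound 2 (0.29 log units; within the scatter). Compound 3 `Cc1cccc(-c2nnc(CSc3nnc(/N=C/c4ccccc4O)s3)o2)c1` differs from compound 1 by 3-methylphenyl in place of 2-chlorophenyl on an aromatic carbon. Within the data shown here, the only measured step that bears on this is the swap from compound 1 to compound 2, which stayed within the scatter, so no change beyond the scatter is expected for the step of a 1.6-fold lower number from compound 1 to compound 3 (0.22 log units; within the scatter). For compound 3 the expected value is 11000 nM, estimated to lie between 4500 nM and 30000 nM.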

Compound 3, half-maximal inhibitory concentration: 11600 nM
The estimate for compound 3 lay 1.1-fold (0.02 log units) below the measured number, and the stated range covers the measured number.
By their numbers in this assay, from the lowest: compounds 2, 3 and 1 (each within the scatter of the next).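

Changing 2-methylphenyl to 3-methylphenyl (a 1.2-fold higher number from compound 2 to compound 3 (0.09 log units; within the scatter)) and 2-chlorophenyl to 3-methylphenyl (a 1.6-fold lower number from compound 1 to compound 3 (0.19 log units; within the scatter)) both stay within the scatter in this assay. On this aromatic carbon of the five-membered ring, shifting the methyl around the phenyl ring therefore gives no change that can be told from scatter, and neither does the swap from 2-chlorophenyl to 3-methylphenyl. Going by these compounds, whether an amine or a carboxylic acid on this phenyl ring would move the number beyond the scatter remains open. Nothing available speaks to why these numbers stay so close.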